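This account rests on a few compounds, and the source may have more. Where it says the series, first, only, none or still open, it means among the compounds named here.

Compound 3 `COc1cc(OC)cc(N2CCN(C(=O)c3oc(C)nc3-c3ccccc3)CC2)c1` is the strongest of the two numbered compounds in a functional assay on HL-60 cells (Homo sapiens) for inhibition, read by MTT assay, with a stated time of 72 h; a lower number here means a stronger inhibitor, a higher number a weaker inhibitor: compound 3 gives 19.2 nM, and compound 1 `Cc1nc(-c2ccccc2)c(C(=O)N2CCN(c3ccc(Cl)c(Cl)c3)CC2)o1` gives 124 nM. The third member of the set, compound 2 `C=C(C)c1ccc(N2CCN(C(=O)c3oc(C)nc3-c3ccccc3)CC2)cc1`, carries no number at all in this assay and is recorded simply as "not active" (no number reported). Compound 4 `Cc1ccc(C)c(N2CCN(C(=O)c3oc(C)nc3-c3ccccc3)CC2)c1` differs from compound 3 in one place: 2,5-dimethylphenyl in place of 3,5-dimethoxyphenyl on an amine nitrogen in a ring. Among the measured compounds shown here, the only measured step that touches this same position is a 6.5-fold lower number from compound 1 to compound 3 (0.81 log units; beyond the scatter), and compound 2, which also varies only the group on the ring nitrogen, lost activity altogether. Together these show that this assay responds strongly to what sits on that nitrogen, so a step beyond the scatter is expected for compound 4. A move toward a higher number, that is a weaker inhibitor, is estimated as a 4.2-fold higher number from compound 3 to compound 4 (0.62 log units; beyond the scatter). Compound 4 is expected to give about 80 nM, with a plausible range from 15 nM to 400 nM.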

Compound 4, half-maximal inhibitory concentration: 31.3 nM
Compound 4: middle estimate off by 2.6-fold (0.41 log units), on the high side, and the stated range covers the measured number.
By their numbers in this assay, from the lowest: compounds 3 and 4 (each within the scatter of the next); then compound 1.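

In this assay, the change on the ring nitrogen gives a 1.6-fold higher number from compound 3 to compound 4 (0.21 log units; within the scatter) and so removes both oxygen atoms and the hydrogen-bond acceptors counted on the leaving group without a change beyond the scatter, which means these are not needed for a low number among these compounds. The same 2,5-dimethylphenyl group also gives a 4.0-fold lower number from compound 1 to compound 4 (0.60 log units; beyond the scatter) in place of 3,4-dichlorophenyl, yet compound 2, which also has a substituent of carbon only on its benzene ring, is recorded as "not active", so having only carbon in this group does not settle the outcome. No measurement at hand explains these differences.

The compounds shown leave open how a phenyl group bearing an amine or a carboxylic acid would behave on this nitrogen. They also leave open whether a single methyl on that phenyl group would be enough.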